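Replacing the Amide End Group of Compound 1

The source may hold more compounds than are shown below. What is called first, only, known or untested is meant among the compounds shown, and "the series" means these compounds.

Measured compounds and their values:
Compound 1, `O=C(Nc1ccccc1)c1cnc(NCc2c(F)ccc3c2CCO3)n2cnnc12`: 14 mL.min-1.g-1
Compound 2, `Cc1ncccc1-c1cnc(NCc2c(F)ccc3c2CCO3)n2c(=O)[nH]nc12`: 36 mL.min-1.g-1
Compound 3, `CC(=O)N1CCC(c2cnc(NCc3c(F)ccc4c3CCO4)c3cn[nH]c(=O)c23)CC1`: 207 mL.min-1.g-1

All three compounds were tested in an ADME assay on microsomes from liver (Homo sapiens) for metabolic stability, read by LC-MS, using NADPH, with stated times of 5 min and 30 min, tested at 1 uM; on this read-out lower numbers stand for slow clearance and higher numbers for fast clearance. Among the three numbers, compound 1 stands at the lowest. Compound 2 is the nearest to it, and the gap between them is beyond the usual scatter of repeated measurements; compound 3 is the furthest away, with a gap that is far beyond the scatter. For the measured compounds named here, no two of these three compounds differ in just one place, so none of the measured pairs shows directly what a single structural change does to the read-out.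

Compound 4, `COCCC(=O)Nc1cnc(NCc2c(F)ccc3c2CCO3)n2cnnc12`, is the next compound to be measured. It differs from compound 1 in one place: ((2-methoxyethyl)carbonyl)amino in place of phenylcarbamoyl on an aromatic carbon. The shared core and the rest of the molecule stay the same. Going by the values given here, no measured pair shows a change of this kind. The size of the step is therefore uncertain. The expectation is a modest rise in the number, a step of a 1.8-fold higher number from compound 1 to compound 4 (0.25 log units; within the scatter) that may or may not exceed the scatter. For compound 4 the estimated value in this assay is 25 mL.min-1.g-1, with a range from 8 mL.min-1.g-1 to 80 mL.min-1.g-1.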

Compound 4, intrinsic clearance in microsomes: < 3 mL.min-1.g-1
Compound 4: only a limit was reported (the forecaster's own chance of this, stated with the estimate: 5%); middle value at least 8.3-fold (0.92 log units) away from the limit.
By their numbers in this assay, from the lowest: compound 1; then compound 2; then compound 3. At a limit, below all of these: compound 4.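

In this assay, for the compounds shown here, placing ((2-methoxyethyl)carbonyl)amino instead of phenylcarbamoyl on this aromatic carbon gives an at least 4.6-fold lower number from compound 1 to compound 4 (0.66 log units; beyond the scatter), the first direct reading of a single change on the shared core. The result for compound 4, < 3 mL.min-1.g-1, is a limit of the assay and not a number. The six-membered aromatic ring of the phenylcarbamoyl group is therefore not needed for a low number at this position, and a chain with no ring goes lower still, though the step gives only the smallest possible size of the change, set by one reading: the limit of < 3 mL.min-1.g-1 in this assay, at which 1 of the 4 values shown sits.

On these data alone, this single pair changes several things at once: the ring goes, the chain gains an oxygen, and the amide is attached to the core through its nitrogen rather than its carbonyl, so the share of each in the step remains unknown. As far as these compounds go, it also remains open whether a simple acetylamino group, a plain amine or a carboxylic acid on the same aromatic carbon would give a number as low, or whether the methoxy end of the chain matters at all.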